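The source may report more compounds than this note shows. Statements on the series, on what has been measured and on what is new or still open speak of the compounds shown alone.

Working notes on the series. Compound 1 `COc1ccccc1/C=c1/[nH]c(=O)/c(=C\c2ccccc2OC)[nH]c1=O` is reported in a functional assay on BGC-823 cells (Homo sapiens) for cytotoxicity, read by CCK-8 assay, with a stated time of 72 h (on this read-out higher numbers stand for weaker inhibition and lower numbers for stronger inhibition), as "not active" (no number reported), with no figure attached. Compound 2 `C=CCn1c(=O)/c(=C\c2cc(F)ccc2C)[nH]c(=O)/c1=C\c1ccccc1OC` holds the only number shown, giving 1600 nM in this assay, so there is nothing else to rank it against. Compound 3 `C=CCn1c(=O)/c(=C\c2cc(Br)ccc2F)[nH]c(=O)/c1=C\c1ccccc1OC` differs from compound 2 in one place: 5-bromo-2-fluorophenyl in place of 5-fluoro-2-methylphenyl on a double-bonded chain carbon bound to an aromatic carbon. Going by the values given here, no step between measured compounds is available to gauge this change, so no shift beyond the usual scatter is expected in this assay. Compound 3 is expected to give 1600 nM, within 600 nM and 4500 nM. The expected step is no change at the digits printed from compound 2 to compound 3 (within the scatter), essentially none.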

Compound 3, half-maximal inhibitory concentration: "not active" (no number reported)
For compound 3 the study gives words and no number; no gap can be computed for the estimate.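

No step can be read from compound 2 to compound 3, as compound 3 is reported without a number. The compounds shown leave open how large the gap between them is. No supporting measurement bears on this result.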